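The source may hold more compounds than are shown below. What is called first, only, known or untested is meant among the compounds shown, and "the series" means these compounds.

Measured compounds:
compound 1 `CC(C)(C)OC(=O)/C=C/c1ccc2c(c1)C(=O)C(=O)N2Cc1ccc(Br)cc1`, 2050 nM
compound 2 `COC(=O)/C=C/c1cccc2c1N(Cc1ccc(OC)cc1)C(=O)C2=O`, > 10000 nM
compound 3 `COC(=O)/C=C/c1ccc2c(c1)C(=O)C(=O)N2Cc1ccc(Cl)c(Cl)c1`, 160 nM

In a functional assay on HepG2 cells (Homo sapiens) for cytotoxicity, read by MTT assay, with a stated time of 48 h (a lower number here means a stronger inhibitor, a higher number a weaker inhibitor), compound 3 gives 160 nM, the lowest of the two numbers recorded; the nearest, compound 1, gives 2050 nM, a gap beyond the scatter. For compound 2 the value of > 10000 nM is a limit of this assay, not a number (the limit of > 10000 nM in this assay, at which 1 of the 3 values shown sits).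

The unmeasured compound 4 `CCN1C(=O)C(=O)c2cc(/C=C/C(=O)OC)ccc21` differs from compound 3 in one place: methyl in place of 3,4-dichlorophenyl on a saturated chain carbon bound to an amide-type nitrogen in a ring. Among the measured compounds shown here, no single-change step between measured compounds is available here, so the size of this step can only be expected, not read off. The change removes the whole six-membered aromatic ring with its two chlorines and leaves a short chain on the ring nitrogen. The account expects the number in this assay to rise, by a step beyond the scatter, making compound 4 the weaker inhibitor.

Compound 4 is expected to give 2500 nM in this assay, within a range of 600 nM to 10000 nM, which means an expected step of a 16-fold higher number from compound 3 to compound 4 (1.19 log units; beyond the scatter).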

Compound 4, half-maximal inhibitory concentration: 400 nM
Beside the measured number, compound 4's estimate is 6.3-fold (0.80 log units) above it; measured number outside the range, below it.
By their numbers in this assay, from the lowest: compound 3; then compound 4; then compound 1. At a limit, above all of these: compound 2.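

Among the compounds shown here, replacing 3,4-dichlorophenyl with methyl on a saturated chain carbon bound to an amide-type nitrogen in a ring gives, in this assay, a 2.5-fold higher number from compound 3 to compound 4 (0.40 log units; beyond the scatter), the first single-change reading at this place. The whole aromatic ring and both its chlorines can therefore go at a modest cost, and compound 4 , with only the short chain left, still gives 400 nM in this assay. Nothing measured among these compounds bears on why the step has this size.

The compounds shown leave open how much of the step belongs to the ring and how much to its two chlorines, which an unsubstituted phenyl at this place would separate. They also leave open how the number moves with a longer chain or with an amine carried on that chain.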